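This account rests on a few compounds, and the source may have more. Where it says the series, first, only, none or still open, it means among the compounds named here.

Compound 1 `CCC1=C(O)c2c(oc(-c3ccc(OC)cc3)cc2=O)C(CC)(CC)C1=O`: 17.7 uM
Compound 2 `CCC1=C(O)c2c(oc(-c3ccc(COC)cc3)cc2=O)C(CC)(CC)C1=O`: > 52.4 uM

In a functional assay on KB cells (Homo sapiens) for antiproliferative activity, read by sulforhodamine B assay, with a stated time of 3 days (on this read-out higher numbers stand for an effect only at larger amounts of compound and lower numbers for an effect already at smaller amounts), compound 1 gives 17.7 uM. Compound 2 reaches only the limit of this assay, > 52.4 uM, so its true number is not known. Within the data shown here, the single measured step, an at least 2.9-fold higher number from compound 1 to compound 2 (0.47 log units; beyond the scatter), therefore rests on the limit of > 52.4 uM in this assay, at which 1 of the 2 values shown sits, and sets only a floor on how much weaker compound 2 is. Compound 3 `CCC1=C(O)c2c(oc(-c3ccc(C)cc3C)cc2=O)C(CC)(CC)C1=O` is not yet measured. It differs from compound 2 by 2,4-dimethylphenyl in place of 4-(methoxymethyl)phenyl on an aromatic carbon. The measured step concerns the same group and shows that changing it can move the read-out beyond the scatter, but it does not tell whether the 2,4-dimethylphenyl will behave more like the methoxy of compound 1 or the methoxymethyl of compound 2. Compound 3 is expected to fall near 30 uM, within 8 uM to 100 uM. That estimate would mean a step of an at least 1.7-fold lower number from compound 2 to compound 3 (0.24 log units; that floor lies within the scatter), with a real chance that this assay again reports only a limit.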

Compound 3, concentration for half-maximal effect: 41.2 uM
For compound 3 the middle estimate is 1.4-fold (0.14 log units) below the measured one; the measured number falls inside the stated range.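

Changing the 4-methoxyphenyl to 2,4-dimethylphenyl, which has no hydrogen-bond acceptor, gives a 2.3-fold higher number from compound 1 to compound 3 (0.37 log units; beyond the scatter) in this assay, so a second, fully measured change at this position also leaves the number higher than with the 4-methoxyphenyl. Unlike compound 2, which reached only a limit, compound 3 gives a real number here, showing that this position can carry an oxygen-free group and still give a measurable effect. The remaining step, an at least 1.2-fold lower number from compound 2 to compound 3 (0.10 log units; that floor lies within the scatter) and no more, puts neither compound ahead of the other, because it rests on a limit: the limit of > 52.4 uM in this assay, at which 1 of the 3 values shown sits.

Compound 3 changes two things at once relative to compound 1, so the shown compounds cannot separate the effect of the added methyl from that of losing the methoxy oxygen. On these data alone, how an amine or a carboxylic acid on this phenyl ring would read also remains open.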